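The source may hold more compounds than are shown below. What is called first, only, known or untested is meant among the compounds shown, and "the series" means these compounds.

The measured compounds in the series:

compound 1 `CN(C)C(=O)c1cc2cnc(Nc3ccc(NC(=O)C4(C(=O)Nc5cccc(O)c5)CC4)cc3)nc2n1C1CCCC1` — -19.8%
compound 2 `CN(C)C(=O)c1cc2cnc(Nc3ccc(NC(=O)C4(C(=O)Nc5ccc(F)cc5)CC4)cc3F)nc2n1C1CCCC1` — 6.6%
compound 3 `CN(C)C(=O)c1cc2cnc(Nc3ccc(NC(=O)C4(C(=O)Nc5cccc(Br)c5)CC4)cc3)nc2n1C1CCCC1` — 13.9%

All three were run in a functional assay on SiHa cells (Homo sapiens) for inhibition, read by CCK-8 assay, with a stated time of 72 h, tested at 1 uM; on this read-out lower numbers stand for less inhibition of growth and higher numbers for more inhibition of growth at the one concentration tested. Compound 1 stands lowest of the three numbers shown; compound 2 is nearest to it and compound 3 furthest, and both gaps lie beyond the scatter. Among the measured compounds shown here, the one step that changes a single place is a number 33.7 percentage points higher from compound 1 to compound 3 (beyond the scatter), a large rise in this assay.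

Compound 4 `Cc1ccc(NC(=O)C2(C(=O)Nc3ccc(Nc4ncc5cc(C(=O)N(C)C)n(C6CCCC6)c5n4)cc3)CC2)cc1` is not yet measured. Relative to compound 1 the change is 4-methylphenyl in place of 3-hydroxyphenyl on an amide-type nitrogen. The step to compound 3 bears on it most closely, since that step also removes the hydroxy from the same aromatic ring and it was large and upward. Compound 2 carries a different change and only its value can be compared, which also lies well above compound 1. On this basis the team expects an upward step in this assay, a number 31.8 percentage points higher from compound 1 to compound 4 (beyond the scatter), rather than none. Compound 4 is estimated at 12%, in a range from -6% to 28%.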

Compound 4, percent growth inhibition at one concentration: 37%
Beside the measured number, compound 4's estimate is 25 percentage points below it; the measured number lies above the stated range.
By their numbers in this assay, from the lowest: compound 1; then compounds 2 and 3 (each within the scatter of the next); then compound 4.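

The change on the amide-type nitrogen was not used up by the step to 3-bromophenyl: in this assay there is a number 56.8 percentage points higher from compound 1 to compound 4 (beyond the scatter), and the 4-methylphenyl group also stands clear of the bromo compound, with a number 23.1 percentage points higher from compound 3 to compound 4 (beyond the scatter). The position therefore responds to more than the loss of the hydroxy, since two replacements of the 3-hydroxyphenyl group give rises of different size. No measurement is available to explain why the 4-methylphenyl group gives the higher number.

The step from compound 3 to compound 4 alters both the substituent and its place on the ring, so the compounds shown cannot separate the two, and a 3-methylphenyl or 4-bromophenyl group would bear on that. Also open, as far as these compounds go, is how an amine, a carboxylic acid or a longer chain at the 4-position of this ring would read.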